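The source may report more compounds than this note shows. Statements on the series, on what has been measured and on what is new or still open speak of the compounds shown alone.

In an assay on CHO cells for displacement of a labelled ligand from prostaglandin E2 receptor EP3 subtype (Mus musculus), read by scintillation counting, with a stated time of 60 min (on this read-out lower numbers stand for stronger inhibition and higher numbers for weaker inhibition), three compounds have been measured. Compound 1, `CCCc1cccc(C[C@H](O)/C=C/[C@H]2CCC(=S)N2CCCCCCC(=O)O)c1`, gives 2000 nM in this assay. Compound 3, `CCc1cccc(C[C@H](O)/C=C/[C@H]2CSC(=O)N2CCSCCCC(=O)O)c1`, gives 65 nM. Compound 2, `O=C(O)CCCSCCN1C(=O)OC[C@@H]1/C=C/[C@@H](O)Cc1cccc(-c2ccccc2)c1`, is reported only as a limit of the assay, > 10000 nM. Compound 2 thus stands at the limit of > 10000 nM in this assay, at which 1 of the 3 values shown sits, and no number for it is known.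

Compound 4, `O=C(O)CCCSCCN1C(=O)OC[C@@H]1/C=C/[C@@H](O)Cc1cccc(Cl)c1`, differs from compound 2 in a single place: chloro in place of phenyl on an aromatic carbon. The core of compound 2 and its acid-bearing chain are kept unchanged.

Among the measured compounds shown here, no measured pair of compounds differs in only this way, so the size of the step is a matter of expectation drawn from the three values. Compound 3, which carries a small ethyl group on its aromatic ring rather than a phenyl, gives 65 nM, although its core also differs from that of compound 2. On this basis the expected step is an at least 33-fold lower number from compound 2 to compound 4 (1.52 log units; beyond the scatter), downward in the read-out and beyond the usual scatter, with the reservation that compound 2 is a limit and the true size cannot be fixed. Compound 4 is estimated at 300 nM, with a range from 60 nM to 2000 nM.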

Compound 4, inhibition constant: 630 nM
Estimate against measurement, compound 4: 2.1-fold (0.32 log units) below; low and high end bracket the measured number.
By their numbers in this assay, from the lowest: compound 3; then compound 4; then compound 1. At a limit, above all of these: compound 2.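

In this assay, the aromatic carbon meta to a large group proves sensitive to what it carries: with the core and the acid-bearing chain kept, chloro in place of phenyl gives an at least 15-fold lower number from compound 2 to compound 4 (1.20 log units; beyond the scatter), a large step. Among the compounds shown here, this is the first change in a single place that can be read, since the earlier compounds offered no such pair and could show only that values differ among compounds differing in several places. Going by these compounds, the step has only a lower bound, and its true size stays unknown, because compound 2 is reported at a limit: the limit of > 10000 nM in this assay, at which 1 of the 4 values shown sits.

What the compounds shown leave open is whether the change in number follows from losing the phenyl or from gaining the chloro, and how a fluoro, methoxy or trifluoromethyl group on the same carbon would read. On these data alone, compound 1 and compound 3 each differ from compound 4 in more than one place, so no further steps can be read, and whether the same exchange would act alike on their cores remains unknown.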